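Extending the hydroxycarbamoyl chain on compound 1

A few compounds are considered here, and "the series" means these few. Any claim that something is new, unique, unknown or untested is made for them only; others in the source may bear on it.

In a functional assay on MDA-MB-231 cells (Homo sapiens) for inhibition, read by MTT assay, with a stated time of 72 h (a higher number here means a weaker inhibitor, a lower number a stronger inhibitor), compound 1 `Nc1ncnc2c1c(-c1cnc3[nH]ccc3c1)nn2CC(=O)NO` gives > 150000 nM as a limit, not a number. Compound 2 `Nc1nc2cc(-c3nn(CCC(=O)NO)c4ncnc(N)c34)ccc2o1` gives > 50000 nM in this assay as well, again a limit, so no measured value yet anchors this comparison. Compound 3 `Nc1ncnc2c1c(-c1cnc3[nH]ccc3c1)nn2CCC(=O)NO` carries (hydroxycarbamoyl)methyl in place of hydroxycarbamoyl on a saturated chain carbon bound to an aromatic nitrogen on the core of compound 1. In this assay only a modest shift toward stronger inhibition is expected, and another limit is quite possible. The expected step of an at least 2.5-fold lower number from compound 1 to compound 3 (0.39 log units; beyond the scatter) is small. Compound 3 is estimated at 60000 nM with 10000 nM to 200000 nM as the expected range.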

Compound 3, half-maximal inhibitory concentration: > 150000 nM
Compound 3 gave a limit, no number; the forecaster's own chance of this, stated with the estimate: 60%; middle value at least 2.5-fold (0.39 log units) from the limit.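

In this assay compound 1 gives > 150000 nM, a limit. Compound 3 gives > 150000 nM, also a limit, so no step can be read between these two compounds. The compounds shown leave open whether (hydroxycarbamoyl)methyl in place of hydroxycarbamoyl changes inhibition at all.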